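Swapping a Hydroxyl for a Methylamine on the Sulfur Chain

The source may hold more compounds than are shown below. What is called first, only, known or untested is meant among the compounds shown, and "the series" means these compounds.

Three compounds have been measured in a functional assay on HT cells (Homo sapiens) for antiproliferative activity, read by fluorescence, with a stated time of 72 h; a lower number here means a stronger inhibitor of growth, a higher number a weaker inhibitor of growth:

Compound 1 `CC(O)CSc1nc(NCc2ccc(-c3ccccn3)cc2)c2[nH]nc(C(C)C)c2n1`: 62 nM
Compound 2 `CC(C)c1n[nH]c2c(NCc3ccc(-c4ccccn4)cc3)nc(SC(C)C(C)O)nc12`: 190 nM
Compound 3 `CC(C)c1n[nH]c2c(NCc3ccc(-c4ccccn4)cc3)nc(SCC(N)CN)nc12`: 480 nM

Compound 1 has the lowest number of the three and is therefore the strongest growth inhibitor here. Its nearest neighbour is compound 2, with a 3.1-fold higher number from compound 1 to compound 2 (0.49 log units; beyond the scatter); the furthest is compound 3, with a 7.7-fold higher number from compound 1 to compound 3 (0.89 log units; beyond the scatter).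

Compound 4 `CNCCSc1nc(NCc2ccc(-c3ccccn3)cc2)c2[nH]nc(C(C)C)c2n1` has not yet been measured. It differs from compound 1 in one place: (methylamino)methyl in place of 1-hydroxyethyl on a saturated chain carbon bound to a sulfur. Within the data shown here, two measured steps bear on this change, since both trade a hydroxyl-bearing group for an amine-bearing one on the sulfur chain. The step of a 7.7-fold higher number from compound 1 to compound 3 (0.89 log units; beyond the scatter) and the step of a 2.5-fold higher number from compound 2 to compound 3 (0.40 log units; beyond the scatter) both gave higher numbers, each beyond the scatter. Compound 4 carries a single amine rather than two, so a somewhat smaller rise is expected. Compound 4 is therefore expected to show a 3.2-fold higher number from compound 1 to compound 4 (0.51 log units; beyond the scatter), giving an estimated 200 nM with a range from 80 nM to 500 nM.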

Compound 4, concentration for 50% growth inhibition: 56 nM
For compound 4 the middle estimate is 3.6-fold (0.55 log units) above the measured one; measured number below the stated range.
By their numbers in this assay, from the lowest: compounds 4 and 1 (each within the scatter of the next); then compound 2; then compound 3.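

Placing (methylamino)methyl in place of 1-hydroxyethyl on a saturated chain carbon bound to a sulfur gives a 1.1-fold lower number from compound 1 to compound 4 (0.04 log units; within the scatter), so this position can hold an amine without a measurable loss of growth inhibition. Compound 3 alone could not show this, and the amine-bearing chains clearly do not behave alike: the chain of compound 4 gives an 8.6-fold lower number from compound 3 to compound 4 (0.93 log units; beyond the scatter) and also a 3.4-fold lower number from compound 2 to compound 4 (0.53 log units; beyond the scatter), so swapping a hydroxyl for an amine does not by itself set the number. Nothing measured here gives a reason for these differences.

Which feature of the chain of compound 3 goes with its higher number remains open. A 2-aminoethyl chain would test whether the methyl on the amine matters, and a 3-(methylamino)propyl chain would test the effect of a longer chain.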